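This account rests on a few compounds, and the source may have more. Where it says the series, first, only, none or still open, it means among the compounds named here.

Compound 1, `O=C(C/C=C/c1ccccc1)Nc1nc2ccccc2c(=O)s1`, carries a phenyl group on a short unsaturated chain linked through an amide to the shared core. In an assay on CHO cells for displacement of a labelled ligand from adenosine receptor A3 (Homo sapiens), read by scintillation counting, with a stated time of 60 min (a higher number here means a weaker inhibitor, a lower number a stronger inhibitor), compound 1 gives 158 nM, the lowest of the two plain numbers recorded for this set. Compound 2, `O=C(CCc1ccccc1)Nc1nc2ccccc2c(=O)s1`, has the same chain without the double bond; in this assay compound 2 gives 390 nM, a higher number whose gap to compound 1 lies beyond the usual scatter of repeat measurements. Compound 3, `O=C(/C=C/c1cccc(Cl)c1)Nc1nc2ccccc2c(=O)s1`, with a chlorine on the phenyl ring and a shorter chain, reaches only a limit of the assay in this assay, > 1000 nM; this is the case described by the limit of > 1000 nM in this assay, at which 1 of the 3 values shown sits.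

Compound 4, `COc1cccc(/C=C/CC(=O)Nc2nc3ccccc3c(=O)s2)c1`, has not yet been measured. It differs from compound 1 in one place: methoxy in place of hydrogen on an aromatic carbon. Going by the values given here, no measured pair in this set shows what a methoxy group at that position does. Compound 1 and compound 2 differ in the chain, not the ring, and compound 3 changes both chain and ring at once, so no direction can be read from them. The step is therefore expected to be small, a 1.4-fold higher number from compound 1 to compound 4 (0.14 log units; within the scatter), within or only just beyond the scatter. Compound 4 is thus estimated at 220 nM, with a likely range from 70 nM to 700 nM.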

Compound 4, inhibition constant: 115 nM
Estimate against measurement, compound 4: 1.9-fold (0.28 log units) above; measured number inside the range.
By their numbers in this assay, from the lowest: compounds 4 and 1 (each within the scatter of the next); then compound 2. At a limit, above all of these: compound 3.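

Swapping phenyl for 3-methoxyphenyl on the chain of compound 1 gives a 1.4-fold lower number from compound 1 to compound 4 (0.14 log units; within the scatter) in this assay and so leaves the number where repeat measurements could have placed it anyway. Going by these compounds alone, this is the first reading of a change on the phenyl ring alone, since compound 2 differs from compound 1 only in the chain and compound 3 differs in both chain and ring; it shows that a methoxy group can sit on this aromatic carbon, meta to a large group, without a step beyond the scatter. Nothing in the data shown gives a reason why the number holds when this group enters.

The compounds shown leave open whether an amine, a hydroxyl group or a carboxylic acid on this same carbon would also leave the number in place, and whether a longer ether such as ethoxy would do the same. They also leave open whether a methoxy group on another carbon of the ring, or on the ring of compound 2, would give a step of similar size.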